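The compounds below may be only part of what the source reports. "The series", "measured", "known", "first", "only" and "open" are said of these compounds alone.

Compound 1 `CC(C)(C)c1ccc(-n2nc(-c3ccc(C(F)(F)F)cc3O)nc2-c2ccccc2O)cc1`: 81.1%
Compound 2 `Oc1cc(C(F)(F)F)ccc1-c1nc(-c2ccccc2O)n(-c2ccc(I)cc2)n1`: 105%
Compound 3 `Cc1ccc(-n2nc(-c3ccc(C(F)(F)F)cc3O)nc2-c2ccccc2O)c(C)c1`: 106%

All three were tested in a functional assay on PC-12 cells (Rattus norvegicus) for cytotoxicity, read by MTT assay, with stated times of 2 h and 24 h, tested at 10 uM; a lower number here means a weaker effect, a higher number a stronger effect of the compound at the concentration tested. Compound 2 stands second highest of the three numbers: its nearest neighbour is compound 3, reached by a number 1 percentage points higher from compound 2 to compound 3 (within the scatter), while compound 1 lies farthest away, as seen in a number 23.9 percentage points higher from compound 1 to compound 2 (beyond the scatter). Compound 4 `Cc1cc(C)cc(-n2nc(-c3ccc(C(F)(F)F)cc3O)nc2-c2ccccc2O)c1` has not yet been measured. It differs from compound 2 in one place: 3,5-dimethylphenyl in place of 4-iodophenyl on an aromatic nitrogen. The step that bears most directly on this change, where the 4-iodophenyl also gives way to a methyl-bearing phenyl, was small and within the scatter. A larger move was seen only against the tert-butyl compound, in a number 24.9 percentage points higher from compound 1 to compound 3 (beyond the scatter). A step of a number 1 percentage points lower from compound 2 to compound 4 (within the scatter) is therefore expected, nothing beyond the scatter. Compound 4 is estimated at 104%, within the range 90% to 118%.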

Compound 4, a percentage reported as activity, at one concentration (the size of the read-out at that concentration, not a potency): 105%
The estimate for compound 4 lay 1 percentage points below the measured number; the measured number falls inside the stated range.
By their numbers in this assay, from the lowest: compound 1; then compounds 2, 4 and 3 (each within the scatter of the next).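

On the aromatic nitrogen, 3,5-dimethylphenyl cannot be told apart from 4-iodophenyl in this assay, with no change at the digits printed from compound 2 to compound 4 (within the scatter), or from 2,4-dimethylphenyl, with a number 1 percentage points lower from compound 3 to compound 4 (within the scatter). Among these groups, neither the iodine nor the placing of the two methyl groups separates the numbers, and only 4-(tert-butyl)phenyl stands apart, with a number 23.9 percentage points higher from compound 1 to compound 4 (beyond the scatter). No measurement shown here gives a reason for this. On these data alone, it remains open whether a phenyl group carrying an amine or a carboxylic acid would group with compound 4 or with compound 1.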